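A few compounds are considered here, and "the series" means these few. Any claim that something is new, unique, unknown or untested is made for them only; others in the source may bear on it.

Compound 1 `COc1ccc(/C=C(/F)c2cc(OC)c(OC)c(OC)c2)cc1O` and compound 2 `COc1ccc(/C=C(/F)c2cc(OC)c(OC)c(OC)c2)cc1[N+](=O)[O-]` share one core and differ in a single place: nitro in place of hydroxy on an aromatic carbon. In a functional assay on HT-29 cells (Homo sapiens) for cytotoxicity, read by sulforhodamine B assay, with a stated time of 72 h (a higher number here means a weaker inhibitor, a lower number a stronger inhibitor), compound 1 gives 100 nM, while compound 2 gives 32 nM. The step is a 3.1-fold lower number from compound 1 to compound 2 (0.49 log units; beyond the scatter). Compound 3 `COc1ccc(/C(F)=C(/F)c2cc(OC)c(OC)c(OC)c2)cc1O` carries a different core, and how that core differs from the core of compound 1 is not broken down here. In this assay compound 3 gives 110 nM, which sits close to compound 1. Compound 4 `COc1ccc(/C(F)=C(/F)c2cc(OC)c(OC)c(OC)c2)cc1[N+](=O)[O-]` has not yet been measured and differs from compound 3 by the same change, at the same kind of place: nitro in place of hydroxy on an aromatic carbon. Because the earlier swap gave a 3.1-fold lower number from compound 1 to compound 2 (0.49 log units; beyond the scatter) and compound 3 gives 110 nM, the step from compound 3 to compound 4 is expected to be about a 3.1-fold lower number from compound 3 to compound 4 (0.50 log units; beyond the scatter). Compound 4 is estimated at 35 nM, probably between 15 nM and 80 nM.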

Compound 4, half-maximal inhibitory concentration: 1310 nM
Compound 4: middle estimate off by 37-fold (1.57 log units), on the low side; the measured number lies above the stated range.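

On the core of compound 3, nitro in place of hydroxy gives a 12-fold higher number from compound 3 to compound 4 (1.08 log units; beyond the scatter) in this assay. Within the data shown here, the same swap therefore moves the number in opposite directions on the two cores, so its result on one core could not be carried over to the other: the same change on two cores in this assay, a 3.1-fold lower number (0.49 log units; beyond the scatter) from compound 1 to compound 2 and a 12-fold higher number (1.08 log units; beyond the scatter) from compound 3 to compound 4, 37-fold (1.57 log units) apart, beyond the scatter of two such steps This is only one comparison of two pairs, and it does not show which feature of the cores separates them or whether other changes would carry over.

The compounds shown leave open whether an amine or a nitrile on the same aromatic carbon would also differ between these two cores. They also leave open whether the same split would appear in any other test.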